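Phenylhydrazone series: replacing the methoxyphenyl arm

The source may hold more compounds than are shown below. What is called first, only, known or untested is meant among the compounds shown, and "the series" means these compounds.

Among the compounds with values here, compound 3 `COc1ccc(N/N=C2\CCC(C)n3c2ncc(C(=O)O)c3=O)cc1` is the only member of the series with a number in a functional assay on the whole organism for inhibition, with Rattus norvegicus as the target; a lower number here means that less compound is needed, a higher number that more compound is needed for the effect; in that assay compound 3 gives 7.6 umol/kg. Compound 1 `CC1CC/C(=N\Nc2cccc(Cl)c2)c2ncc(C(=O)O)c(=O)n21` in this assay gives only a limit, > 100 umol/kg. Compound 2 `CC1CC/C(=N\Nc2ccc(Br)cc2)c2ncc(C(=O)O)c(=O)n21` in this assay likewise gives only a limit, > 1000 umol/kg. Both of these are limits rather than numbers: the limit of > 100 umol/kg in this assay, at which 1 of the 3 values shown sits, and (the limit of > 1000 umol/kg in this assay, at which 1 of the 3 values shown sits). The readable steps therefore run an at least 13-fold lower number from compound 1 to compound 3 (1.11 log units; beyond the scatter) and an at least 130-fold lower number from compound 2 to compound 3 (2.11 log units; beyond the scatter), each a large fall toward compound 3, while the step that the two limits leave unreadable from compound 1 to compound 2 stays unreadable between two limits.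

Compound 4 `Cc1cccc(N/N=C2\CCC(C)n3c2ncc(C(=O)O)c3=O)c1` carries 3-methylphenyl in place of 4-methoxyphenyl on an amine nitrogen. The change takes away the methoxy that both readable steps share on arriving at compound 3, but what enters is a methyl rather than a halogen, so neither step maps onto it directly. The expectation is a rise in the number in this assay, of a size a 5.3-fold higher number from compound 3 to compound 4 (0.72 log units; beyond the scatter), with a real chance that only a limit is reported. Compound 4 is expected at 40 umol/kg, within a range from 10 umol/kg to 200 umol/kg.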

Compound 4, dose for 50% inhibition: 72.5 umol/kg
Compound 4: the middle estimate sits 1.8-fold (0.26 log units) below what was measured, and the stated range covers the measured number.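

Within the data shown here, replacing the 4-methoxyphenyl arm with 3-methylphenyl on an amine nitrogen gives a 9.5-fold higher number from compound 3 to compound 4 (0.98 log units; beyond the scatter) in this assay, the first step with a measured number at both ends. Compound 2 gives only a limit, and the change to 3-methylphenyl gives an at least 13-fold lower number from compound 2 to compound 4 (1.13 log units; beyond the scatter), which shows that an arm without methoxy can still lie well apart from the 4-bromophenyl arm. Compound 1 also gives only a limit, and methyl in place of chloro on an aromatic carbon gives an at least 1.3-fold lower number from compound 1 to compound 4 (0.13 log units; that floor lies within the scatter), a floor that does not show a real difference between these two arms.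

Compound 3 and compound 4 differ in both the group and where it stands on the phenyl arm, and 4-methylphenyl and 3-methoxyphenyl arms would be needed to tell those two changes apart. On these data alone, whether a 4-ethoxyphenyl or 4-aminophenyl arm would match or improve on the 4-methoxyphenyl arm in this assay also remains open.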